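Swapping the amino group for difluoromethyl on the shared core

This account rests on a few compounds, and the source may have more. Where it says the series, first, only, none or still open, it means among the compounds named here.

In an ADME assay on cells for inhibition of cytochrome P450 11B1, mitochondrial (Homo sapiens), read by HPLC, with a stated time of 60 min (a lower number here means a stronger inhibitor, a higher number a weaker inhibitor), compound 3 `CN(C)c1ncncc1-c1nc2cc(F)c(F)cc2n1C1CC1` gives 4630 nM, the highest of the three numbers shown. Compound 1 `CCc1ncncc1-c1nc2cc(F)c(F)cc2n1C1CC1` gives 3330 nM, and compound 2 `CNc1ncncc1-c1nc2cc(F)c(F)cc2n1C1CC1` gives 390 nM. Compound 4 `Fc1cc2nc(-c3cncnc3C(F)F)n(C3CC3)c2cc1F` has not yet been measured; it differs from compound 3 in difluoromethyl in place of dimethylamino on an aromatic carbon. Among the measured compounds shown here, the steps that bear on this are a 1.4-fold higher number from compound 1 to compound 3 (0.14 log units; within the scatter), an 8.5-fold lower number from compound 1 to compound 2 (0.93 log units; beyond the scatter) and a 12-fold higher number from compound 2 to compound 3 (1.07 log units; beyond the scatter). Within this set only the methylamino group of compound 2 stands apart; exchanging one group without a hydrogen-bond donor for another, as a 1.4-fold higher number from compound 1 to compound 3 (0.14 log units; within the scatter) shows, left the number within the scatter. Compound 4 is therefore expected to lie near compound 1 and compound 3, with a 1.9-fold lower number from compound 3 to compound 4 (0.27 log units; within the scatter) as the expected step. The estimate for compound 4 is 2500 nM, ranging from 800 nM to 8000 nM.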

Compound 4, half-maximal inhibitory concentration: 4330 nM
For compound 4 the middle estimate is 1.7-fold (0.24 log units) below the measured one, within the range that was stated.
By their numbers in this assay, from the lowest: compound 2; then compounds 1, 4 and 3 (each within the scatter of the next).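

Difluoromethyl on this aromatic carbon stays level with dimethylamino (a 1.1-fold lower number from compound 3 to compound 4 (0.03 log units; within the scatter)) and ethyl (a 1.3-fold higher number from compound 1 to compound 4 (0.11 log units; within the scatter)), even though it brings no hydrogen-bond acceptor where dimethylamino brought one. Methylamino thus stands apart from three groups without a hydrogen-bond donor, not two (an 11-fold higher number from compound 2 to compound 4 (1.05 log units; beyond the scatter)). Nothing available here accounts for this gap. From the compounds shown here alone, whether an unsubstituted amino group or ethylamino would stand with methylamino remains open. So does whether methoxy or hydroxyl would stand with the other three groups or apart from them.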